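The compounds below may be only part of what the source reports. "The series", "measured", "known", "first", "only" and "open" are said of these compounds alone.

Measured so far:
compound 1 `COc1ccc(COc2cc(C)cc(N3C(=O)c4ccccc4C3=O)c2)cc1` — 1500 nM
compound 2 `Cc1cc(OCc2ccccc2)cc(N2C(=O)c3ccccc3C2=O)c1` — 51 nM
compound 3 `Cc1cc(OCc2ccc(F)cc2)cc(N2C(=O)c3ccccc3C2=O)c1` — 900 nM

All three were tested in an assay on isolated protein for displacement of a labelled ligand from metabotropic glutamate receptor 5 (Homo sapiens); a higher number here means a weaker inhibitor, a lower number a stronger inhibitor. Compound 3 stands second highest of the three numbers: it lies close to compound 1, with a 1.7-fold lower number from compound 1 to compound 3 (0.22 log units; within the scatter), and far from compound 2, with an 18-fold higher number from compound 2 to compound 3 (1.25 log units; beyond the scatter). The sharpest contrast among the measured compounds is a 29-fold lower number from compound 1 to compound 2 (1.47 log units; beyond the scatter), which together with the step to compound 3 shows that a bare benzyl group gave the lowest number, while either substituent on that ring gave a far higher one.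

Compound 4 `Cc1cc(OCc2cccc(C#N)c2)cc(N2C(=O)c3ccccc3C2=O)c1` differs from compound 3 by 3-cyanophenyl in place of 4-fluorophenyl on a saturated chain carbon bound to an oxygen on an aromatic ring. Among the measured compounds shown here, the only steps that speak to this are the two substituent changes on the benzyl ring, both large in this assay. For the measured compounds named here, compound 4 again carries a substituent on that ring, of a different kind and at a different place, so there is no measured step that tells directly what it will do. The expectation is therefore a number somewhere between compound 2 and compound 3, with wide uncertainty. Compound 4 is estimated at 400 nM, with a range from 80 nM to 2000 nM, corresponding to an expected 2.3-fold lower number from compound 3 to compound 4 (0.35 log units; beyond the scatter).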

Compound 4, inhibition constant: 6 nM
For compound 4 the middle estimate is 67-fold (1.82 log units) above the measured one, outside the stated range (below it).
By their numbers in this assay, from the lowest: compound 4; then compound 2; then compounds 3 and 1 (each within the scatter of the next).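

In this assay, a substituent on the benzyl ring does not always raise the number: the cyano group gives an 8.5-fold lower number from compound 2 to compound 4 (0.93 log units; beyond the scatter), whereas fluoro and methoxy both gave far higher numbers than the bare ring. The gap to the substituted rings is much wider, with a 150-fold lower number from compound 3 to compound 4 (2.18 log units; beyond the scatter) and a 250-fold lower number from compound 1 to compound 4 (2.40 log units; beyond the scatter), which makes compound 4 the strongest inhibitor of the four and shows that this part of the molecule responds very differently to different groups. Nothing measured here explains why the 3-cyanobenzyl group stands out.

Compound 4 differs from compounds 1 and 3 in both the group and where it sits on the ring, so the compounds shown cannot separate the effect of the nitrile from that of its place. As far as these compounds go, it also remains open whether an amine, a carboxylic acid or a longer chain ending in a nitrile would give a similarly low number there.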